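Working notes: from compound 3 to compound 4

This account rests on a few compounds, and the source may have more. Where it says the series, first, only, none or still open, it means among the compounds named here.

Measured so far:
compound 1 `CC(=O)N1N=C(Nc2nc3ccccc3s2)CC1OC1=CC=C1` – "not determined" (no result reported)
compound 2 `COc1ccc(C2CC(Nc3nc4ccc(Cl)cc4s3)=NN2C(C)=O)cc1` – 97.3 umol/kg
compound 3 `CC(=O)N1N=C(Nc2nc3ccc(Cl)cc3s2)CC1OC1=CC=C1` – "not determined" (no result reported)

In a functional assay on the whole organism (strain albino) with Mus musculus as the target, with a stated time of 0.5 h (on this read-out lower numbers stand for an effect already at smaller amounts and higher numbers for an effect only at larger amounts of compound), only compound 2 gives a number, namely 97.3 umol/kg. For compound 1 the entry is "not determined" (no result reported) and for compound 3 the entry is "not determined" (no result reported), so compound 3 stands without any number and cannot be placed against compound 2. Going by the values given here, no step between two measured compounds exists in this set.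

The next compound is compound 4 `CC(=O)N1N=C(Nc2nc3ccc(Cl)cc3s2)CC1c1ccc(O)cc1`. It differs from compound 3 by the following change: a group of 7 heavy atoms (6 carbon, 1 oxygen; one six-membered aromatic ring of carbon only) in place of a group of 5 heavy atoms (4 carbon, 1 oxygen; one four-membered non-aromatic ring of carbon only), on a saturated ring carbon.

Among the compounds with values here, since compound 3 has no measured value, no step in this assay can be expected in either direction from it; any expectation for compound 4 has to rest on compound 2 alone, because compound 2 gives 97.3 umol/kg and shares the acetyl-bearing five-membered ring with a six-membered aromatic ring on its saturated carbon. On that basis compound 4 is estimated to come out close to compound 2 in this assay, at about 100 umol/kg, with a likely range from 30 umol/kg to 320 umol/kg. This is an estimate from a single measured compound and carries wide uncertainty.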

Compound 4, dose for half-maximal effect: 107 umol/kg
Estimate against measurement, compound 4: 1.1-fold (0.03 log units) below; low and high end bracket the measured number.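

In this assay the series gains its first readable step, a 1.1-fold higher number from compound 2 to compound 4 (0.04 log units; within the scatter), with hydrogen in place of methyl on an oxygen on an aromatic ring. The aromatic group on the saturated ring carbon, next to the ring nitrogen, can therefore carry either a free hydroxyl or its methyl ether without a change that stands out from the scatter, and the two compounds are not separated by this assay. No measurement on hand bears on why this exchange leaves the number within the scatter.

The exchange of the four-membered ring group for 4-hydroxyphenyl cannot be read as a step, and neither can any other comparison with compound 1 or compound 3, whose entries carry no number. Also open, from the compounds shown here alone, is whether an amine or a carboxylic acid in place of the hydroxyl on the aromatic ring, or a longer chain on that oxygen, would move the number beyond the scatter.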